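What Compound 4 May Add After Compound 3

The source may hold more compounds than are shown below. What is called first, only, known or untested is meant among the compounds shown, and "the series" means these compounds.

Three measured compounds share one core and differ only on the amine nitrogen of its ring. Compound 1 `CC(C)(C)c1cc(NC(=O)[C@@H]2CCCCN2C2CCOCC2)no1` carries an oxan-4-yl there, and in an ADME assay (liver) for metabolic stability, with Liver microsome (Homo sapiens) as the target, read by LC-MS, using microsomes and NADPH, tested at 1 uM (on this read-out higher numbers stand for a longer-lived compound and lower numbers for a shorter-lived compound), compound 1 gives 0.317 h. Compound 2 `CC(C)(C)c1cc(NC(=O)[C@@H]2CCCCN2C(=O)C2CCCCC2)no1` carries a cyclohexylcarbonyl instead, and in this assay compound 2 gives 0.483 h; the step is a 1.5-fold higher number from compound 1 to compound 2 (0.18 log units; within the scatter). Compound 3 `CC(C)(C)c1cc(NC(=O)[C@@H]2CCCCN2C(=O)C2CCS(=O)(=O)CC2)no1` replaces the cyclohexyl on that carbonyl carbon with a 1,1-dioxothian-4-yl. In this assay compound 3 reaches only a limit, > 2 h, and no number is known for it. The step is an at least 4.1-fold higher number from compound 2 to compound 3 (0.61 log units; beyond the scatter), which places compound 3 at the limit of > 2 h in this assay, at which 1 of the 3 values shown sits.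

Compound 4 `CC(=O)N1CCN(C(=O)N2CCCC[C@H]2C(=O)Nc2cc(C(C)(C)C)on2)CC1` is the next change: 4-acetylpiperazin-1-yl in place of 1,1-dioxothian-4-yl on a carbonyl carbon. The step that bears on it most closely is an at least 4.1-fold higher number from compound 2 to compound 3 (0.61 log units; beyond the scatter), made at the same carbonyl carbon and beyond the scatter; the step of a 1.5-fold higher number from compound 1 to compound 2 (0.18 log units; within the scatter) was within it. Compound 3 sits at a limit; the size of any step from it cannot be read exactly. Compound 4 loses the group that came with the large rise and gains a 4-acetylpiperazin-1-yl, and it is expected to stand above compound 2 without surely reaching the limit. The expected step is an at least 1.3-fold lower number from compound 3 to compound 4 (0.12 log units; that floor lies within the scatter). Compound 4 is estimated at 1.5 h, between 0.5 h and 4 h.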

Compound 4, half-life: > 2 h
Compound 4 ended at the assay's limit; the forecaster's own chance of this, stated with the estimate: 35%; middle value at least 1.3-fold (0.12 log units) away from the limit.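

In this assay compound 4 gives > 2 h, which is a limit of the assay and not a number. Within the data shown here, the earlier compounds showed a rise at this carbonyl carbon with only one group, the 1,1-dioxothian-4-yl; here a second group, the 4-acetylpiperazin-1-yl, which carries no sulfur, also gives an at least 4.1-fold higher number from compound 2 to compound 4 (0.61 log units; beyond the scatter), so the rise over the cyclohexyl is not tied to the sulfone-bearing ring alone. The step between compound 3 and compound 4 cannot be read, so no order can be set between the two groups, and both compounds now rest at the same ceiling of the read-out: the limit of > 2 h in this assay, at which 2 of the 4 values shown sit.

The compounds shown leave open how far compound 3 and compound 4 really lie from each other, and how long either lasts past that limit. They also leave open which part of the 4-acetylpiperazin-1-yl carries the gain, a question that a piperazin-1-yl with a free amine or a morpholin-4-yl on the same carbonyl carbon would address.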